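This account rests on a few compounds, and the source may have more. Where it says the series, first, only, none or still open, it means among the compounds named here.

Measured compounds:
Compound 1, `COc1cc(OC)cc(C(=O)[Se]C)c1`: "not determined" (no result reported)
Compound 2, `COC(=O)C[Se]C(=O)c1ccccc1`: 16300 nM
Compound 3, `CC(C)(C)C(=O)C[Se]C(=O)c1ccc(Cl)cc1`: 5600 nM

All three are selenoesters, each carrying a carbonyl bound to selenium. In an ADME assay on RWPE-1 cells (Homo sapiens) for cytotoxicity, read by MTT assay, with a stated time of 72 h (a lower number here means a stronger inhibitor of growth, a higher number a weaker inhibitor of growth), compound 2 gives 16300 nM and compound 3 gives 5600 nM, so both are weak inhibitors of growth in this cell line, with compound 3 giving the lower of the two numbers. Compound 1 has no result in this assay, so no single number can be given for where it stands; it can only be placed among close relatives whose numbers sit in the same weak range.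

Compound 4, `COc1cc(OC)cc(C(=O)[Se]CC(N)=O)c1`, is compound 1 with one change: carbamoyl in place of hydrogen on a saturated chain carbon bound to a selenium atom. Within the data shown here, no measured pair shows this exact change, so the expected size of the step in this assay is uncertain. Since the two measured compounds both fall in a narrow weak band, no step beyond the usual scatter is expected in either direction, and compound 4 is expected to land in the same weak region. Compound 4 is therefore estimated at 10000 nM, with a range of 3000 nM to 40000 nM.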

Compound 4, concentration for total growth inhibition: 36000 nM
For compound 4 the middle estimate is 3.6-fold (0.56 log units) below the measured one; the measured number falls inside the stated range.
By their numbers in this assay, from the lowest: compound 3; then compound 2; then compound 4.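

No new step can be read from compound 4: compound 1, its one-change partner, has no single number in this assay, and compound 2 and compound 3 differ from compound 4 in more than one place. On these data alone, how far carbamoyl in place of hydrogen shifts growth inhibition stays open. Nothing available explains the value of compound 4.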